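The source may hold more compounds than are shown below. What is called first, only, known or untested is meant among the compounds shown, and "the series" means these compounds.

Measured compounds:
compound 1, `COc1ccc([S+]([O-])c2cn(-c3ccc4c(c3)B(O)OC4)c3ccccc23)cc1`, in an ADME assay on L929 cells (Mus musculus) for cytotoxicity, read by resazurin assay, with a stated time of 72 h; a higher number here means a weaker inhibitor, a lower number a stronger inhibitor: > 10 ug/mL
compound 2, `O=C(c1ccn(-c2ccc3c(c2)B(O)OC3)c1)c1ccccc1Cl`: > 10 ug/mL

In this assay compound 1 gives > 10 ug/mL, which is a limit of the assay rather than a number. Compound 2 likewise gives > 10 ug/mL, also a limit and not a number. Both values sit at the limit of > 10 ug/mL in this assay, at which 2 of the 2 values shown sit, so compound 2 stands at the edge of what the assay reports, and nothing in the numbers separates it from compound 1. Compound 3 is `CCc1ccc(C(=O)c2ccn(-c3ccc4c(c3)B(O)OC4)c2)cc1`. It differs from compound 2 by 4-ethylphenyl in place of 2-chlorophenyl on a carbonyl carbon. Among the compounds with values here, no step between measured compounds is available here, and the only guide is that every measured value is a limit. The step that the limit leaves unreadable from compound 2 to compound 3 is expected to be none beyond the scatter, most likely ending again at a limit. Compound 3 is therefore expected to give about 15 ug/mL, within 6 ug/mL to 40 ug/mL.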

Compound 3, half-maximal inhibitory concentration: > 10 ug/mL
Compound 3 ended at the assay's limit (the forecaster's own chance of this, stated with the estimate: 80%); the middle value lies beyond the limit too.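

No size can be read for the change from 2-chlorophenyl to 4-ethylphenyl between compound 2 and compound 3, since each gives only a limit and not a number: the limit of > 10 ug/mL in this assay, at which 3 of the 3 values shown sit.

The compounds shown leave open how strongly any of them acts in this assay, and whether these two groups differ there at all.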